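A thiophene ring replaces dichlorophenyl on the shared core

This account rests on a few compounds, and the source may have more. Where it says the series, first, only, none or still open, it means among the compounds named here.

Of the compounds shown here, three built on one shared core have been measured in a functional assay on A-375 cells (Homo sapiens) for antiproliferative activity, read by MTT assay, with a stated time of 48 h; on this read-out lower numbers stand for stronger inhibition of growth and higher numbers for weaker inhibition of growth. Compound 1 `Cc1ccc(C2=NN(C(=S)Nc3ccccc3)C(c3ccc4c(c3)OCCO4)C2)cc1` gives 6320 nM. Compound 2 `O=[N+]([O-])c1ccc(C2=NN(C(=S)Nc3ccccc3)C(c3ccc4c(c3)OCCO4)C2)cc1` gives 78100 nM, and the step of a 12-fold higher number from compound 1 to compound 2 (1.09 log units; beyond the scatter) separates these two. Compound 3 `S=C(Nc1ccccc1)N1N=C(c2ccc(Cl)c(Cl)c2)CC1c1ccc2c(c1)OCCO2` gives 41900 nM, the second highest of the three numbers; its gap to compound 2 stays within the scatter, while its gap to compound 1 does not, as the step of a 6.6-fold higher number from compound 1 to compound 3 (0.82 log units; beyond the scatter) shows.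

Compound 4 `S=C(Nc1ccccc1)N1N=C(c2cccs2)CC1c1ccc2c(c1)OCCO2` is not yet measured. It differs from compound 3 in one place: thiophen-2-yl in place of 3,4-dichlorophenyl on a carbon with a double bond to nitrogen. Going by the values given here, two measured steps concern changes of the group on this same carbon. The step of a 6.6-fold higher number from compound 1 to compound 3 (0.82 log units; beyond the scatter) was modest and beyond the scatter, whereas the step of a 1.9-fold lower number from compound 2 to compound 3 (0.27 log units; within the scatter) stayed within it. Groups at this position can therefore shift the number modestly or hardly at all. Among the compounds with values here, no measured compound carries a five-membered aromatic ring with one hetero atom there, so the direction is open, and the expected step of a 2.1-fold lower number from compound 3 to compound 4 (0.32 log units; beyond the scatter) is set close to no change with a wide range. On this basis compound 4 is estimated at 20000 nM, expected to fall between 5000 nM and 80000 nM.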

Compound 4, concentration for 50% growth inhibition: 121000 nM
Beside the measured number, compound 4's estimate is 6.1-fold (0.78 log units) below it, outside the stated range (above it).
By their numbers in this assay, from the lowest: compound 1; then compounds 3, 2 and 4 (each within the scatter of the next, the first and the last beyond it).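

Putting thiophen-2-yl, a five-membered aromatic ring with one hetero atom, on this carbon does not restore growth inhibition in this assay: the change from the dichlorophenyl compound gives a 2.9-fold higher number from compound 3 to compound 4 (0.46 log units; beyond the scatter), while the change from the nitrophenyl compound gives a 1.5-fold higher number from compound 2 to compound 4 (0.19 log units; within the scatter), so these two sit level. The comparison with the methylphenyl compound gives a 19-fold higher number from compound 1 to compound 4 (1.28 log units; beyond the scatter), which makes this the widest gap yet seen from changing the group at this position. Across the four compounds, 3,4-dichlorophenyl, 4-nitrophenyl and thiophen-2-yl all give clearly higher numbers than 4-methylphenyl, so compound 1 remains the most potent, and a five-membered ring in place of a six-membered one offers no advantage here.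

Nothing available here explains why these groups differ as they do. Still open, on these data alone, is whether a 4-methoxyphenyl group, a 4-aminophenyl group or a short ethyl chain on this carbon would come close to compound 1, and whether thiophen-2-yl would behave the same with another group in place of the 2,3-dihydro-1,4-benzodioxin-6-yl group.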